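This account rests on a few compounds, and the source may have more. Where it says the series, first, only, none or still open, it means among the compounds named here.

Measured in a functional assay on Z-138 cells (Homo sapiens) for antiproliferative activity, with a stated time of 72 h; a lower number here means a stronger inhibitor, a higher number a weaker inhibitor:
- compound 1 `Nc1ncnn2c([C@@H]3O[C@H](CO)[C@@H](O)[C@H]3O)cc(C#Cc3ccc(F)cc3)c12`: 89000 nM
- compound 2 `Cc1ccccc1-c1cc([C@@H]2O[C@H](CO)[C@@H](O)[C@H]2O)n2ncnc(N)c12`: 66000 nM

Compound 2 stands within the scatter of compound 1, so these two values cannot be ranked. Compound 3 `Nc1ncnn2c([C@@H]3O[C@H](CO)[C@@H](O)[C@H]3O)cc(-c3ccoc3)c12` carries furan-3-yl in place of 2-methylphenyl on an aromatic carbon. Among the compounds with values here, the only measured step, a 1.3-fold lower number from compound 1 to compound 2 (0.13 log units; within the scatter), exchanged a group at this same place and stayed within the scatter. One step is thin evidence, so a similar result in this assay is expected only tentatively, with no change beyond the scatter. The expected change is a 1.7-fold lower number from compound 2 to compound 3 (0.22 log units; within the scatter). For compound 3 the estimated value is 40000 nM, with an expected range from 3000 nM to 100000 nM.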

Compound 3, half-maximal inhibitory concentration: 300 nM
Beside the measured number, compound 3's estimate is 130-fold (2.12 log units) above it; measured number below the stated range.
By their numbers in this assay, from the lowest: compound 3; then compounds 2 and 1 (each within the scatter of the next).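

On this aromatic carbon of the shared core, the group carried matters strongly in this assay, which the earlier exchange, within the scatter, gave no sign of. Furan-3-yl in place of 2-methylphenyl gives a 220-fold lower number from compound 2 to compound 3 (2.34 log units; beyond the scatter), and furan-3-yl in place of 2-(4-fluorophenyl)ethynyl gives a 300-fold lower number from compound 1 to compound 3 (2.47 log units; beyond the scatter), so both larger groups lie far from furan-3-yl. Nothing measured here accounts for this gain. The compounds shown leave open whether the ring oxygen or the smaller ring goes with the gain. From the compounds shown here alone, how a thiophene ring, an unsubstituted phenyl or an amine on this carbon would read in this assay also remains open.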